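Swapping the aryl group on the piperazine of compound 3

This account rests on a few compounds, and the source may have more. Where it says the series, first, only, none or still open, it means among the compounds named here.

Of the compounds shown here, three have been measured in an assay on HEK293 cells for displacement of a labelled ligand from 5-hydroxytryptamine receptor 7 (Homo sapiens), with a stated time of 1 h; a higher number here means a weaker inhibitor, a lower number a stronger inhibitor. Compound 1 `CSc1ccccc1N1CCN(CCCCC(=O)N2CCC[C@H]2C(N)=O)CC1` gives 163 nM, compound 2 `COc1ccccc1N1CCN(CCCCC(=O)N2CCC[C@H]2C(N)=O)CC1` gives 634 nM, and compound 3 `NC(=O)[C@@H]1CCCN1C(=O)CCCCCN1CCN(c2cccc(Cl)c2)CC1` gives 478 nM. Compound 3 thus stands second highest of the three numbers: its value lies within the scatter of compound 2, while against compound 1 it is beyond the scatter, compound 1 being the lower number. Among the compounds with values here, the only step recorded among the measured compounds is a 3.9-fold higher number from compound 1 to compound 2 (0.59 log units; beyond the scatter), which concerns the group on the aromatic carbon and does not touch the change now considered.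

Compound 4 `NC(=O)[C@@H]1CCCN1C(=O)CCCCCN1CCN(c2ccc(F)cc2)CC1` differs from compound 3 by 4-fluorophenyl in place of 3-chlorophenyl on an amine nitrogen in a ring. Within the data shown here, no measured pair shows this kind of exchange of one aryl group for another, so the expectation rests only on the value of compound 3 itself and on the general observation that changes on the aryl ring have moved numbers by modest amounts in this set. The estimate for compound 4 is therefore a step of a 1.5-fold higher number from compound 3 to compound 4 (0.17 log units; within the scatter), with the value expected near 700 nM and a range from 250 nM to 2000 nM in this assay.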

Compound 4, inhibition constant: 1190 nM
Estimate against measurement, compound 4: 1.7-fold (0.23 log units) below; the range from low to high includes it.
By their numbers in this assay, from the lowest: compound 1; then compounds 3, 2 and 4 (each within the scatter of the next, the first and the last beyond it).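

In this assay, putting 4-fluorophenyl in place of 3-chlorophenyl on the amine nitrogen in the ring gives a 2.5-fold higher number from compound 3 to compound 4 (0.40 log units; beyond the scatter). This shows that, with the rest of compound 3 unchanged, exchanging one aryl group for another at this nitrogen can move the number beyond the scatter, even though both groups have the same count of heavy atoms and neither has hydrogen-bond donors or acceptors. No supporting measurement is available to explain this difference.

Halogen and ring place change together in this step, so the compounds shown cannot separate the two; a phenyl with fluorine where compound 3 has chlorine would address this. Also open, going by these compounds, is how methylsulfanyl, present in compound 1, would behave on the chain of compound 3.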